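Lengthening the ester chain of compound 3

The source may hold more compounds than are shown below. What is called first, only, known or untested is meant among the compounds shown, and "the series" means these compounds.

In an ADME assay on Vero cells (Chlorocebus sabaeus) for cytotoxicity, read by MTT assay (a lower number here means a stronger inhibitor, a higher number a weaker inhibitor), compound 3 (`CCCCCCCCCC(=O)OCC(C)(C)CC1=C(O)C(=O)c2ccccc2C1=O`) gives 203000 nM and stands level with compound 1 (`CCCCCC(=O)OCC(C)(C)CC1=C(O)C(=O)c2ccccc2C1=O`) at 169000 nM while compound 2 (`CCCCCCC(=O)OCC(C)(C)CC1=C(O)C(=O)c2ccccc2C1=O`) gives 99300 nM here. Compound 4 (`CCCCCCCCCCCCCC(=O)OCC(C)(C)CC1=C(O)C(=O)c2ccccc2C1=O`) has butyl in place of hydrogen on a saturated chain carbon, nine bonds along the chain from a carbonyl carbon. The closest measured precedent, also a butyl addition, is a 1.2-fold higher number from compound 1 to compound 3 (0.08 log units; within the scatter) and the other two steps are a 1.7-fold lower number from compound 1 to compound 2 (0.23 log units; within the scatter) and a 2.0-fold higher number from compound 2 to compound 3 (0.31 log units; beyond the scatter) so these three compounds show no steady direction with chain length. No step beyond the scatter is therefore expected in this assay and the estimated change is a 1.1-fold lower number from compound 3 to compound 4 (0.03 log units; within the scatter) only. For compound 4 the expected value is 190000 nM with an estimated range from 90000 nM to 400000 nM in this measurement.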

Compound 4, half-maximal inhibitory concentration: 58400 nM
Compound 4: the middle estimate sits 3.3-fold (0.51 log units) above what was measured; measured number outside the range, below it.
By their numbers in this assay, from the lowest: compounds 4, 2, 1 and 3 (each within the scatter of the next, the first and the last beyond it).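

In this assay the butyl added nine bonds along the chain from a carbonyl carbon gives a 3.5-fold lower number from compound 3 to compound 4 (0.54 log units; beyond the scatter) and so moves the number beyond the scatter, which the butyl added five bonds along did not do. The long chain also parts from the shortest, with a 2.9-fold lower number from compound 1 to compound 4 (0.46 log units; beyond the scatter) as the step, but not from compound 2, with a 1.7-fold lower number from compound 2 to compound 4 (0.23 log units; within the scatter) as the step, so the series still shows no steady direction. No evidence at hand accounts for this result. As far as these compounds go, whether a longer chain would hold this level, and what an amine or a carboxylic acid in place of the butyl would do, stays open.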